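Halogen swap on the acetamide side chain

The source may report more compounds than this note shows. Statements on the series, on what has been measured and on what is new or still open speak of the compounds shown alone.

Measured so far:
- compound 1, `S=C=Nc1ccc(OCC2=NCCN2)cc1`, 117%
- compound 2, `O=C(CI)Nc1ccc(CC2=NCCN2)cc1`, 13%
- compound 3, `S=C=Nc1ccc(CC2=NCCN2)cc1I`, 28%

Notes on the series. In an ADME assay on the whole organism (thoracic aorta) with Rattus norvegicus as the target (a lower number here means a smaller maximal response, a higher number a larger maximal response), compound 2 gives 13%, the lowest of the three numbers. The nearest value is that of compound 3, which gives 28%, a gap beyond the scatter; the furthest is compound 1, which gives 117%, far beyond the scatter. No pair among these three differs in only one place, so no single-change step is known for this assay.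

The next compound, compound 4, `O=C(CCl)Nc1ccc(CC2=NCCN2)cc1`, differs from compound 2 by a single change: chloro in place of iodo on a saturated chain carbon bound to a carbonyl carbon. Among the measured compounds shown here, the difference is confined to one atom on a saturated chain carbon bound to a carbonyl carbon, and no directly comparable step is available to calibrate it. In this assay a small step is expected, if any, most likely upward and possibly not beyond the scatter. The expected step of a number 17 percentage points higher from compound 2 to compound 4 (beyond the scatter) reflects this. For compound 4 the largest response is estimated at 30%, with a range from 8% to 65%.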

Compound 4, largest response reached (Emax), in percent of the reference or control that the assay uses: 32%
Beside the measured number, compound 4's estimate is 2 percentage points below it, and the stated range covers the measured number.
By their numbers in this assay, from the lowest: compound 2; then compounds 3 and 4 (each within the scatter of the next); then compound 1.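

Chloro in place of iodo on a saturated chain carbon bound to a carbonyl carbon gives the first single-change step in this series: in this assay the change produces a number 19 percentage points higher from compound 2 to compound 4 (beyond the scatter) and so moves the result beyond the scatter. The largest response therefore depends on which halogen sits at this position, even though one heavy atom replaces one heavy atom and no ring, hydrogen-bond donor, hydrogen-bond acceptor or net charge enters or leaves. No measurement at hand accounts for the direction or size of this step.

On these data alone, whether bromo or fluoro on the same carbon would fit this direction remains open, as does the response with an amine or a longer chain there. A single pair also cannot show whether the same halogen swap would act alike on another core.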